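Removing the Isopropyl Branch: Compound 3 to Compound 4

The source may hold more compounds than are shown below. What is called first, only, known or untested is meant among the compounds shown, and "the series" means these compounds.

The series rests on a shared core carrying a boronate ester and two fluorophenyl arms. Compound 1 `CC(C)C[C@H](NC(=O)N1CCN(C(=O)N2C/C(=C\c3ccc(F)cc3)C(=O)/C(=C/c3ccc(F)cc3)C2)CC1)B1OC(C)(C)C(C)(C)O1` gives 1630 nM in a functional assay on HCT-116 cells (Homo sapiens) for antiproliferative activity, read by MTT assay, with a stated time of 72 h; on this read-out higher numbers stand for weaker inhibition and lower numbers for stronger inhibition. Compound 2 `CC(C)C[C@H](NC(=O)N1C/C(=C\c2ccc(F)cc2)C(=O)/C(=C/c2ccc(F)cc2)C1)B1OC(C)(C)C(C)(C)O1` gives 824 nM in this assay. Compound 3 `CC(C)C[C@H](NC(=O)[C@@H](NC(=O)N1C/C(=C\c2ccc(F)cc2)C(=O)/C(=C/c2ccc(F)cc2)C1)C(C)C)B1OC(C)(C)C(C)(C)O1` gives 534 nM in this assay, the lowest of the three numbers; the gap to compound 2 lies within the scatter, while the gap to compound 1 lies beyond it, so compound 3 can only be said to inhibit more strongly than compound 1.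

Compound 4 `CC(C)C[C@H](NC(=O)CNC(=O)N1C/C(=C\c2ccc(F)cc2)C(=O)/C(=C/c2ccc(F)cc2)C1)B1OC(C)(C)C(C)(C)O1` has not yet been measured. It differs from compound 3 by hydrogen in place of isopropyl on a saturated chain carbon bound to an amide-type nitrogen and a carbonyl carbon. For the measured compounds named here, no pair among the measured compounds shows this change, so the data give no step to lean on. The three compounds vary in the linker between the core and the boronate-bearing unit, and the spread among them is modest. He expects the step of a 1.9-fold higher number from compound 3 to compound 4 (0.27 log units; within the scatter) in this assay to be small, probably a slight weakening that may not exceed the scatter. He therefore estimates compound 4 at 1000 nM in this assay, with a range from 400 nM to 2500 nM.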

Compound 4, half-maximal inhibitory concentration: 375 nM
Beside the measured number, compound 4's estimate is 2.7-fold (0.43 log units) above it, outside the stated range (below it).
By their numbers in this assay, from the lowest: compounds 4, 3, 2 and 1 (each within the scatter of the next, the first and the last beyond it).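

In this assay, for the compounds shown here, this is the first reading of hydrogen in place of isopropyl on a saturated chain carbon bound to an amide-type nitrogen and a carbonyl carbon, and it gives a 1.4-fold lower number from compound 3 to compound 4 (0.15 log units; within the scatter). The isopropyl group, with its 3 carbon atoms, can therefore leave this place with no change beyond the scatter, so its presence is not required for a value in this range. This single pair shows that one substitution at this carbon is tolerated, but it establishes no trend across substituents at this place.

The compounds shown leave open whether a methyl group, a benzyl group or a chain ending in an amine or a carboxylic acid at this carbon would also stay within the scatter of compound 4. Nothing available bears on why the isopropyl group can leave without a change beyond the scatter.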